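This account rests on a few compounds, and the source may have more. Where it says the series, first, only, none or still open, it means among the compounds named here.

Measured compounds:
compound 1 `NC1CCN(c2c(-c3cc(F)cc(Cl)c3)cncc2-c2nc3cc(F)ccc3[nH]2)CC1`, 0.081 nM in a functional assay on CHO-K1 cells for agonist activity at somatostatin receptor type 2 (Homo sapiens), read by cAMP accumulation, with a stated time of 30 min; a higher number here means that more compound is needed for the effect, a lower number that less compound is needed;
compound 2 `Cc1cc(C)cc(C(=O)Nc2cncc(-c3cc(C)cc(C)c3)c2N2CCC(N)CC2)c1`, 0.04 nM in this assay.

Compound 1 has the higher of these two numbers; the gap to compound 2 lies beyond the usual scatter. Compound 3 `Cc1cc(C)cc(-c2cncc(-c3nc4cc(F)ccc4[nH]3)c2N2CCC(N)CC2)c1` is not yet measured. It differs from compound 1 in one place: 3,5-dimethylphenyl in place of 3-chloro-5-fluorophenyl on an aromatic carbon. Compound 2 also carries a 3,5-dimethylphenyl group and gives 0.04 nM. For compound 3 a small step toward a lower number in this assay is therefore expected, near the edge of the scatter, as a 1.4-fold lower number from compound 1 to compound 3 (0.13 log units; within the scatter). The estimate for compound 3 is 0.06 nM, with a range from 0.02 nM to 0.2 nM.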

Compound 3, half-maximal effective concentration: 0.013 nM
For compound 3 the middle estimate is 4.6-fold (0.66 log units) above the measured one, and the stated range ends above it.
By their numbers in this assay, from the lowest: compound 3; then compound 2; then compound 1.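

On this aromatic carbon, two atoms from the ring nitrogen, 3,5-dimethylphenyl in place of 3-chloro-5-fluorophenyl gives a 6.2-fold lower number from compound 1 to compound 3 (0.79 log units; beyond the scatter) in this assay. The position is therefore sensitive to what the phenyl ring carries, even though both groups have the same count of heavy atoms and neither has hydrogen-bond donors or acceptors. Nothing measured here explains this difference. As far as these compounds go, it remains open whether one methyl group would give the same result as two. Also open, from the compounds shown here alone, is how 3,5-dimethoxyphenyl or an aminophenyl group would read at this position.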